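The compounds below may be only part of what the source reports. "The series", "measured", "known", "first", "only" and "open" are said of these compounds alone.

Compound 2 `NC1CCN(c2nc3c(c(Nc4ccc(C(F)(F)F)cc4)n2)CCN(c2ncccc2C(F)(F)F)CC3)C1` carries 3-aminopyrrolidin-1-yl on the shared core. In a physicochemical assay for solubility, in phosphate buffer, measured as thermodynamic solubility, at pH 2 (a higher number here means a more soluble compound, a lower number a less soluble compound), compound 2 gives > 215 ug/mL, a limit of the assay. Compound 1 `FC(F)(F)c1ccc(Nc2nc(NC3CCCNC3)nc3c2CCN(c2ncccc2C(F)(F)F)CC3)cc1` in this assay gives > 235 ug/mL, also a limit. The step that the two limits leave unreadable from compound 1 to compound 2 is thus not readable, since both values sit at limits: the limit of > 215 ug/mL in this assay, at which 1 of the 2 values shown sits, and (the limit of > 235 ug/mL in this assay, at which 1 of the 2 values shown sits). Compound 3 `CNC1CCN(c2nc3c(c(Nc4ccc(C(F)(F)F)cc4)n2)CCN(c2ncccc2C(F)(F)F)CC3)C1` differs from compound 2 by methyl in place of hydrogen on an amine nitrogen. Going by the values given here, no measured step bears on this change, and the only measured step is unreadable. Compound 3 is expected to sit at the limit again, a step that the limit leaves unreadable from compound 2 to compound 3 of no readable size. The estimate for compound 3 is 250 ug/mL, within 120 ug/mL to 500 ug/mL.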

Compound 3, solubility: > 220 ug/mL
Compound 3: only a limit was reported; the forecaster's own chance of this, stated with the estimate: 80%; the middle value is on the limit's open side.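

Going by these compounds alone, compound 1, compound 2 and compound 3 all sit at limits in this assay, so no step among them can be read. Still open, from the compounds shown here alone, are their actual values and whether methyl in place of hydrogen on an amine nitrogen changes them.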